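Swapping a Trifluoromethyl for a Methanesulfonamido Group

The source may report more compounds than this note shows. Statements on the series, on what has been measured and on what is new or still open speak of the compounds shown alone.

Measured so far:
compound 1, `CC(C)(C)c1cc(NC(=O)Nc2ccc(F)cc2)n(-c2ccccc2)n1`, gives -2.2 degrees C in an assay on isolated protein for inhibition of Ephrin type-A receptor 2 (Homo sapiens), read by thermal shift assay, tested at 10 uM; on this read-out higher numbers stand for stronger stabilisation of the target against heat and lower numbers for weaker stabilisation of the target
compound 2, `CC(C)(C)c1cc(NC(=O)Nc2ccc(Cl)cc2)n(-c2ccc(C(F)(F)F)cc2)n1`, gives 0.6 degrees C in this assay

Of these two, compound 2 stands highest, and its number lies above that of compound 1 by more than the usual scatter. Compound 3, `CC(C)(C)c1cc(NC(=O)Nc2ccc(Cl)cc2)n(-c2ccc(NS(C)(=O)=O)cc2)n1`, has not yet been measured. It differs from compound 2 in one place: methanesulfonamido in place of trifluoromethyl on an aromatic carbon. For the measured compounds named here, no measured pair here shows what this exchange does. The step in this assay is expected to be small, possibly none beyond the scatter: a number 0.10 degrees C lower from compound 2 to compound 3 (within the scatter). Compound 3 is therefore estimated at 0.5 degrees C, with a range from -1.5 degrees C to 2.5 degrees C.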

Compound 3, shift of the target's melting temperature: 2.8 degrees C
The estimate for compound 3 lay 2.3 degrees C below the measured number; the measured number lies above the stated range.
By their numbers in this assay, from the lowest: compound 1; then compound 2; then compound 3.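

In this assay the group on this aromatic carbon clearly matters: methanesulfonamido in place of trifluoromethyl gives a number 2.2 degrees C higher from compound 2 to compound 3 (beyond the scatter) with the rest of the molecule unchanged. For the compounds shown here, this is the first one-place comparison here, and it shows that a group carrying a hydrogen-bond donor and acceptors can sit at this place with stronger stabilisation of the target. Nothing available gives a reason for this rise.

On these data alone, it remains open whether an amine, a carboxylic acid or the longer ethanesulfonamido chain at this place would give a similar rise. As far as these compounds go, it is also open whether methanesulfonamido would give the same step with fluoro in place of the chloro of compound 3.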